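The source may hold more compounds than are shown below. What is called first, only, known or untested is meant among the compounds shown, and "the series" means these compounds.

Compound 1 `Oc1ccc(C2C/C(=N\NC(=S)N3CCOCC3)c3ccc(O)cc3O2)cc1`: 76300 nM
Compound 2 `Oc1ccc(C2C/C(=N\NC(=S)N3CCCC3)c3ccc(O)cc3O2)cc1`: 65200 nM

Both compounds were tested in a functional assay on HeLa cells (Homo sapiens) for cytotoxicity, read by MTT assay, with a stated time of 72 h; on this read-out higher numbers stand for weaker inhibition and lower numbers for stronger inhibition. For the measured compounds named here, compound 1 gives 76300 nM, which lies within the usual scatter of compound 2, its only measured neighbour, so no order can be set between them. Compound 3 `CCCN(CCC)C(=S)N/N=C1\CC(c2ccc(O)cc2)Oc2cc(O)ccc21` keeps the core of compound 1 and carries dipropylamino in place of morpholin-4-yl on a thiocarbonyl carbon. Going by the values given here, one measured step bears on this, a swap at the same place, with pyrrolidin-1-yl entering: a 1.2-fold lower number from compound 1 to compound 2 (0.07 log units; within the scatter). That step stays within the scatter, but its incoming group is a ring, and no open-chain group has been measured here. No clear step is therefore expected in this assay, and the direction stays uncertain. The estimated step is a 1.3-fold lower number from compound 1 to compound 3 (0.10 log units; within the scatter). For compound 3 the expected value is 60000 nM, with an estimated range from 25000 nM to 120000 nM.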

Compound 3, half-maximal inhibitory concentration: 75300 nM
Beside the measured number, compound 3's estimate is 1.3-fold (0.10 log units) below it; the range from low to high includes it.
By their numbers in this assay, from the lowest: compounds 2, 3 and 1 (each within the scatter of the next).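

In this assay the swap to open-chain dipropylamino on the thiocarbonyl carbon gives a 1.0-fold lower number from compound 1 to compound 3 (0.01 log units; within the scatter) and a 1.2-fold higher number from compound 2 to compound 3 (0.06 log units; within the scatter) when set against the ring-bearing compounds. Until now only ring groups had been compared at this place, and these steps show that an amine without a ring also stays within the scatter of both. No measurement on hand explains why the three compounds cannot be told apart.

From the compounds shown here alone, what remains open is whether any group at this place can move the number beyond the scatter, such as the smaller dimethylamino, the longer dihexylamino or the aromatic anilino. The compounds shown also leave open how the number responds to changes elsewhere on the shared core, such as replacing a hydroxyl group with a methoxy group.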